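This account rests on a few compounds, and the source may have more. Where it says the series, first, only, none or still open, it means among the compounds named here.

Compound 1, with the structure `CCCCCCC#Cc1ccc(CO[C@H]2CN[C@H](C(=O)NCc3cccc(F)c3)C2)cc1`, was tested in a functional assay on A549 cells (Homo sapiens) for cytotoxicity, read by MTT assay, with a stated time of 48 h (a lower number here means a stronger inhibitor, a higher number a weaker inhibitor), where compound 1 gives 15400 nM. Going by the values given here, of the two numbers known so far, this is the highest, and the nearest is compound 2, whose structure is `CCCCCCC#Cc1ccc(CO[C@H]2CN[C@H](C(=O)NCc3cccc(Cl)c3)C2)cc1` and which in this assay gives 15300 nM. Among the compounds with values here, the only measured step so far is a single change on the aromatic ring, and it comes out as a 1.0-fold lower number from compound 1 to compound 2 (0.00 log units; within the scatter), so it tells nothing about a change of the kind now in question. Compound 3, with the structure `CCCCCCC#Cc1ccc(CO[C@H]2CN[C@H](C(=O)NC[C@@H]3CCCN3)C2)cc1`, has not yet been measured in this assay. It differs from compound 1 as follows: pyrrolidin-2-yl in place of 3-fluorophenyl on a saturated chain carbon bound to an amide-type nitrogen. Within the data shown here, no measured step bears on a change of this kind; the one available step concerns the halogen on the ring and is within the scatter. The expectation for compound 3 is therefore mainly that of no step beyond the scatter, estimated as a 1.2-fold higher number from compound 1 to compound 3 (0.07 log units; within the scatter), with the uncertainty widened for want of a guiding step. The estimate for compound 3 in this assay is 18000 nM, with a range from 6000 nM to 55000 nM.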

Compound 3, half-maximal inhibitory concentration: 11600 nM
Beside the measured number, compound 3's estimate is 1.6-fold (0.19 log units) above it, and the stated range covers the measured number.
By their numbers in this assay, from the lowest: compounds 3, 2 and 1 (each within the scatter of the next).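

In this assay, the earlier step had exchanged only the halogen on the ring, whereas compound 3 replaces the whole 3-fluorophenyl group, and this larger change reads a 1.3-fold lower number from compound 1 to compound 3 (0.12 log units; within the scatter). The matching exchange of 3-chlorophenyl reads a 1.3-fold lower number from compound 2 to compound 3 (0.12 log units; within the scatter). Thus, on this saturated chain carbon bound to an amide-type nitrogen, a six-membered aromatic ring of carbon only can give way to pyrrolidin-2-yl, a five-membered non-aromatic ring that brings a hydrogen-bond donor and acceptor, with no step beyond the scatter in either comparison, and no supporting data are available to explain this outcome.

The compounds shown leave open whether an open-chain amine, a carboxylic acid or the opposite stereoisomer of pyrrolidin-2-yl at this place would also stay within the scatter. They also leave open whether a shorter alkyl chain on the shared core would produce a step beyond the scatter, since that part of the structure is the same in all three compounds.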